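From Phenyl to Methyl on the Amine Chain

The source may hold more compounds than are shown below. What is called first, only, known or untested is meant among the compounds shown, and "the series" means these compounds.

Among the compounds with values here, in an ADME assay on L6 cells (Rattus norvegicus) for cytotoxicity (on this read-out higher numbers stand for weaker inhibition and lower numbers for stronger inhibition), compound 3 (`COc1cc2c(cc1C(C)NCCCc1ccccc1)CCC(C)(C)O2`) gives 2630 nM as the lowest of three numbers so far. Compound 1 (`COc1ccc(CNC(C)c2cc3c(cc2OC)OC(C)(C)C=C3)cc1`) reads 14900 nM and compound 2 (`CCNC(C)c1cc2c(cc1OC)OC(C)(C)C=C2`) reads 176000 nM on the same read-out. Compound 4 (`CCCCNC(C)c1cc2c(cc1OC)OC(C)(C)CC2`) has not yet been measured. It departs from compound 3 by one change (methyl in place of phenyl on a saturated chain carbon, three bonds along the chain from an amine nitrogen) that puts methyl in place of phenyl on a saturated chain carbon, three bonds along the chain from an amine nitrogen. Within the data shown here, the only measured step that bears on this is a 12-fold higher number from compound 1 to compound 2 (1.07 log units; beyond the scatter) with methyl in place of 4-methoxyphenyl on a saturated chain carbon bound to an amine nitrogen. That step is a loose guide, as it sits at a different place and the core of compound 1 is not that of compound 3. A change in the same direction but of smaller size is therefore expected, and the expected step is a 6.1-fold higher number from compound 3 to compound 4 (0.78 log units; beyond the scatter) in this assay and likely lies beyond the scatter. The estimate for compound 4 is 16000 nM with an expected range of 5000 nM to 60000 nM.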

Compound 4, half-maximal inhibitory concentration: 59000 nM
The estimate for compound 4 lay 3.7-fold (0.57 log units) below the measured number; low and high end bracket the measured number.
By their numbers in this assay, from the lowest: compound 3; then compound 1; then compound 4; then compound 2.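

The step of a 22-fold higher number from compound 3 to compound 4 (1.35 log units; beyond the scatter) in this assay shows that the number depends strongly on whether phenyl or methyl sits on a saturated chain carbon, three bonds along the chain from an amine nitrogen. Within the data shown here, the only earlier exchange of this kind, a 12-fold higher number from compound 1 to compound 2 (1.07 log units; beyond the scatter) at a different place and on the core of compound 1, ran in the same direction, so the new step extends that direction to a second place and to the core shared by compound 3 and compound 4. No measurement among these data accounts for the step.

From the compounds shown here alone, only phenyl and methyl are compared at this place, so it remains open how a cyclohexyl ring, a pyridine ring or an amine would read there. Going by these compounds, it also remains open whether a longer chain carrying the phenyl would shift the number further.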